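Moving a Hydroxyl Within the Ester Side Chain

The compounds below may be only part of what the source reports. "The series", "measured", "known", "first", "only" and "open" are said of these compounds alone.

Three compounds have been measured in a functional assay on DU-145 cells (Homo sapiens) for cytotoxicity, read by MTT assay; a lower number here means a stronger inhibitor, a higher number a weaker inhibitor:
compound 1, `CC(C)=CC[C@@H](OC[C@H](C)O)C1=CC(=O)c2c(O)ccc(O)c2C1=O`, gives 24500 nM
compound 2, `CCCCC(O)CC(=O)O[C@H](CC=C(C)C)C1=CC(=O)c2c(O)ccc(O)c2C1=O`, gives 45300 nM
compound 3, `CCCC(CC(=O)O[C@H](CC=C(C)C)C1=CC(=O)c2c(O)ccc(O)c2C1=O)OC(C)=O`, gives 55700 nM

Compound 2 holds the second highest of the three numbers. Its nearest neighbour is compound 3, reached by the step of a 1.2-fold higher number from compound 2 to compound 3 (0.09 log units; within the scatter), and its furthest is compound 1, linked by the step of a 1.8-fold higher number from compound 1 to compound 2 (0.27 log units; within the scatter). Both steps stay within the scatter, so the three compounds are not distinguished from one another in this assay.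

Compound 4, `CCCC(C)(O)CC(=O)O[C@H](CC=C(C)C)C1=CC(=O)c2c(O)ccc(O)c2C1=O`, differs from compound 2 by a single rearrangement at the same place where compound 3 was changed:
1-hydroxy-1-methylbutyl in place of 1-hydroxypentyl on a saturated chain carbon bound to a carbonyl carbon

The step from compound 2 to compound 3 is the one that bears most directly on this change, since it alters the same carbon, and it was small; the step from compound 1 to compound 2 was also small. Going by the values given here, nothing measured so far shows this part of the molecule moving the number beyond the scatter. For compound 4 the expected step is therefore a 1.0-fold lower number from compound 2 to compound 4 (0.00 log units; within the scatter), within the scatter. The estimate for compound 4 is 45000 nM, with a range from 20000 nM to 100000 nM.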

Compound 4, half-maximal inhibitory concentration: 75000 nM
Estimate against measurement, compound 4: 1.7-fold (0.22 log units) below, within the range that was stated.
By their numbers in this assay, from the lowest: compounds 1, 2, 3 and 4 (each within the scatter of the next, the first and the last beyond it).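

Putting 1-hydroxy-1-methylbutyl in place of 1-hydroxypentyl, two groups with the same atoms joined differently, gives a 1.7-fold higher number from compound 2 to compound 4 (0.22 log units; within the scatter) in this assay, and putting it in place of 1-acetoxybutyl gives a 1.3-fold higher number from compound 3 to compound 4 (0.13 log units; within the scatter), so neither change on this saturated chain carbon separates the compounds. The only separation in the set comes with the wider change, a 3.1-fold higher number from compound 1 to compound 4 (0.49 log units; beyond the scatter), where (2-hydroxy-2-methylpentyl)carbonyl replaces 2-hydroxypropyl on an oxygen on a saturated carbon. No data here explain that gap.

The compounds shown do not reveal which part of that wider change carries the gap. They also leave open whether an amine or a carboxylic acid at this place, or a longer chain, would move the number beyond the scatter.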